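The compounds below may be only part of what the source reports. "The series", "measured", "known", "first", "only" and "open" are said of these compounds alone.

Compound 1 `CCCc1ccc(C(=O)Nc2cc3nc(C4CCCCC4)[nH]c3cc2N(CC)CC)cc1` — in an ADME assay on Vero cells (Chlorocebus sabaeus) for cytotoxicity, read by resazurin assay, with a stated time of 3 days (on this read-out higher numbers stand for weaker inhibition and lower numbers for stronger inhibition), compound 1 gives "not determined" (no result reported).
Compound 2 `CCN(CC)c1cc2[nH]c(C3CCCCC3)nc2cc1NC(=O)c1ccc(OC(F)F)cc1` — in this assay compound 2 gives > 100 ug/mL, which is a limit of the assay rather than a number.
Compound 3 `CCN(CC)c1cc2[nH]c(C3CCCCC3)nc2cc1NC(=O)c1cnccn1` — in this assay compound 3 gives > 100 ug/mL, again a limit rather than a number.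

All three share one core and differ only in the group on the carbonyl carbon of the amide. Compound 3 therefore stands at the limit, and no number places it above or below compound 2, whose value is also a limit; compound 1 carries no result at all. The step from compound 2 to compound 3, a step that the two limits leave unreadable from compound 2 to compound 3, cannot be sized for that reason.

Compound 4 `C=Cc1cccc(C(=O)Nc2cc3nc(C4CCCCC4)[nH]c3cc2N(CC)CC)c1` is not yet measured. Its difference from compound 3 is 3-vinylphenyl in place of pyrazin-2-yl on a carbonyl carbon. Among the compounds with values here, the only measured step that touches this position is the one from compound 2 to compound 3, and it tells nothing about size or direction. Within the data shown here, the one piece of evidence is the limit of > 100 ug/mL in this assay, at which 2 of the 3 values shown sit, which suggests that the whole series sits at or near the limit in this assay. For compound 4 the expected step of an at least 1.1-fold lower number from compound 3 to compound 4 (0.04 log units; that floor lies within the scatter) is therefore small, with a chance that the result is again a limit. Compound 4 is estimated at 90 ug/mL, between 40 ug/mL and 150 ug/mL.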

Compound 4, half-maximal inhibitory concentration: > 100 ug/mL
Compound 4: a limit, no number (the forecaster's own chance of this, stated with the estimate: 60%); middle value at least 1.1-fold (0.04 log units) away from the limit.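

In this assay compound 4 gives > 100 ug/mL, which is a limit of the assay and not a number. No step can be read among compound 2, compound 3 and compound 4, because all three values are limits: the limit of > 100 ug/mL in this assay, at which 3 of the 4 values shown sit. The compounds shown leave open whether changing the group on the carbonyl carbon alters this read-out at all, and by how much.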